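Amide series: cell toxicity read-out and the next compound

The source may report more compounds than this note shows. Statements on the series, on what has been measured and on what is new or still open speak of the compounds shown alone.

Measured so far:
compound 1 `CSc1ccc2nc(C)cc(OCC(=O)Nc3cc(C)cc(C)c3)c2c1` — > 100000 nM
compound 2 `COc1ccc2nc(C)cc(NC(=O)C(=O)Nc3cc(C)cc(C)c3)c2c1` — > 100000 nM
compound 3 `COc1ccc2nc(C)cc(OCC(=O)Nc3cccc(C)c3)c2c1` — 39800 nM

In a toxicity assay on HepG2 cells (Homo sapiens) for inhibition, read by CellTiter-Glo, with a stated time of 48 h (on this read-out lower numbers stand for stronger inhibition and higher numbers for weaker inhibition), compound 1 gives > 100000 nM, which is a limit of the assay and not a number. Compound 2 gives > 100000 nM in this assay, again a limit. Within the data shown here, compound 3 gives 39800 nM in this assay, the only number among the three values shown; the other two sit at the limit of > 100000 nM in this assay, at which 2 of the 3 values shown sit, so compound 3 is the one compound of the set for which the read-out returned a figure.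

Compound 4 `COc1ccc2nc(C)cc(OCC(=O)Nc3cccnc3)c2c1` differs from compound 3 by pyridin-3-yl in place of 3-methylphenyl on an amide-type nitrogen. Among the measured compounds shown here, no pair of measured compounds differs in a single place, so no measured step gives the size of such a change in this assay. The expected step from compound 3 to compound 4 in this assay is a 2.0-fold higher number from compound 3 to compound 4 (0.30 log units; within the scatter), towards weaker inhibition and of a size that may exceed the scatter. Compound 4 is estimated at 80000 nM in this assay, with a range from 30000 nM to 200000 nM, and a real chance that only a limit is returned.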

Compound 4, half-maximal inhibitory concentration: > 100000 nM
Compound 4 was reported as a limit (the forecaster's own chance of this, stated with the estimate: 55%); middle value at least 1.2-fold (0.09 log units) from the limit.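

Among these compounds, the change on the amide-type nitrogen now has a direction in this assay: pyridin-3-yl in place of 3-methylphenyl gives an at least 2.5-fold higher number from compound 3 to compound 4 (0.40 log units; beyond the scatter), a step towards weaker inhibition and the first single-place comparison. Compound 4 gives > 100000 nM, which is a limit of the assay and not a number, so the step has a lower bound but no exact size. Compound 3 remains the only compound here with a figure, and the read-out is otherwise close to uninformative for ranking: the limit of > 100000 nM in this assay, at which 3 of the 4 values shown sit.

This one change both removes the methyl and places a nitrogen in the ring, and the two contributions cannot be separated from the compounds shown. Unsubstituted phenyl on the same amide-type nitrogen would show whether losing the methyl alone accounts for the step.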